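Removing the Amino Group from a Dichloro-Free Purine Analog

The source may report more compounds than this note shows. Statements on the series, on what has been measured and on what is new or still open speak of the compounds shown alone.

The series is read in a functional assay on HCT-15 cells (Homo sapiens) for cytotoxicity, read by sulforhodamine B assay, with a stated time of 48 h; a lower number here means a stronger inhibitor of growth, a higher number a weaker inhibitor of growth. Compound 1, with the structure `ClCc1cccc(Cn2cnc3c(Cl)nc(Cl)nc32)c1`, gives 6910 nM in this assay. Compound 2, with the structure `Nc1nc(Cl)c2ncn(Cc3ccccc3CCl)c2n1`, gives 7410 nM in this assay. Of the two numbers shown, compound 2 stands at one end, but its gap to compound 1 is within the usual scatter, so the two cannot be told apart on these data.

Compound 3, with the structure `ClCc1ccccc1Cn1cnc2c(Cl)ncnc21`, has not yet been measured in this assay. It differs from compound 2 in one place: hydrogen in place of amino on an aromatic carbon. The amino group at that aromatic carbon is gone and a hydrogen stands in its place; everything else in the shared core and the side chain is kept.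

Among the compounds with values here, no step between measured compounds informs on this change, so the expectation rests on the two values alone. The step from compound 2 to compound 3 is expected to be small, a 1.2-fold higher number from compound 2 to compound 3 (0.08 log units; within the scatter), in the direction of a weaker inhibitor of growth if any, and possibly none beyond the scatter. Compound 3 is therefore estimated at 9000 nM, within a range from 3500 nM to 25000 nM.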

Compound 3, concentration for total growth inhibition: 4670 nM
Estimate against measurement, compound 3: 1.9-fold (0.28 log units) above; the range from low to high includes it.
By their numbers in this assay, from the lowest: compounds 3, 1 and 2 (each within the scatter of the next).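

In this assay, putting hydrogen in place of the amino group on the aromatic carbon between two ring nitrogen atoms gives a 1.6-fold lower number from compound 2 to compound 3 (0.20 log units; within the scatter), so compound 2 and compound 3 cannot be told apart on these data, and in this pair the read-out does not depend measurably on the amino group. Within the data shown here, this is the first step that isolates this position, since compound 1 and compound 2 differ in more than one place and their values could not speak to this change alone. The data shown offer no measurement that would explain this outcome.

Going by these compounds, only amino and hydrogen are compared on this carbon with the rest of the structure kept, so it remains open whether a methoxy or a dimethylamino group there would move the number beyond the scatter. Also open, on these data alone, is whether the same exchange would read the same with the side chain of compound 1, and whether either compound's growth inhibition would hold in cells other than those of this assay.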